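The compounds below may be only part of what the source reports. "The series", "measured", "known", "first", "only" and "open" are said of these compounds alone.

Compounds measured so far:

Compound 1, `Cc1cnc(Nc2ccc(C(C)C)cc2)nc1Nc1nc2ccccc2s1`, gives only a limit of the assay in a functional assay on HeLa cells (Homo sapiens) for antiproliferative activity, read by MTT assay, with a stated time of 48 h (on this read-out lower numbers stand for stronger inhibition and higher numbers for weaker inhibition), namely > 50000 nM.
Compound 2, `COc1cccc(Nc2ncc(C)c(Nc3nc4ccccc4s3)n2)c1`, gives only a limit in this assay, > 50000 nM.
Compound 3, `Cc1cnc(Nc2ccc(F)cc2)nc1Nc1nc2ccccc2s1`, gives only a limit in this assay, > 50000 nM.

All three compounds share the same core and differ only in the group on the aryl amine. Where compound 3 stands can be said only as a limit: it shows no measurable inhibition of cell growth within the range of this assay. The steps between the measured compounds are a step that the two limits leave unreadable from compound 1 to compound 2, a step that the two limits leave unreadable from compound 1 to compound 3 and a step that the two limits leave unreadable from compound 2 to compound 3; none of them can be sized, because of the limit of > 50000 nM in this assay, at which 3 of the 3 values shown sit.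

Compound 4, `COc1ccc(Nc2ncc(C)c(Nc3nc4ccccc4s3)n2)cc1`, is the next compound to be measured. It differs from compound 3 by methoxy in place of fluoro on an aromatic carbon. The measured steps bear on this change only insofar as every change of the aryl group examined so far has left the compound inactive, so no step beyond the scatter, in either direction, can be read from them. The step from compound 3 to compound 4 is therefore estimated as a number no higher from compound 3 to compound 4 (the limit leaves the size open). Compound 4 is expected to give about 50000 nM, within 20000 nM to 100000 nM.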

Compound 4, half-maximal inhibitory concentration: > 50000 nM
Compound 4: no number, only a limit; the forecaster's own chance of this, stated with the estimate: 80%; the middle value sits exactly at the limit.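

Compound 4 also gives only a limit, so the steps linking it to compound 1, compound 2 and compound 3 cannot be read, because every result stops at the same point: the limit of > 50000 nM in this assay, at which 4 of the 4 values shown sit.

The compounds shown leave open how strongly any of them inhibits cell growth, and whether the group changes among them make any difference.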